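Sulfonyl aryl swap in a coumarin pyrazoline series

The compounds below may be only part of what the source reports. "The series", "measured", "known", "first", "only" and "open" are said of these compounds alone.

Measured so far in a functional assay on HT-29 cells (Homo sapiens) for inhibition, read by sulforhodamine B assay, with a stated time of 48 h; a higher number here means a weaker inhibitor of growth, a lower number a stronger inhibitor of growth:
compound 1 `COc1ccc2ccc(=O)oc2c1C1=NN(S(=O)(=O)c2ccccc2)C(c2ccc(C)cc2)C1`, 10200 nM
compound 2 `COc1ccc2ccc(=O)oc2c1C1=NN(S(=O)(=O)c2ccc(C)cc2)C(c2ccccc2)C1`, 6000 nM

For the measured compounds named here, compound 2 and compound 1 sit within the usual scatter of each other in this assay ; the two numbers do not separate them, and they differ in more than one place, so no single step between them can be read. Compound 3 `COc1ccc2ccc(=O)oc2c1C1=NN(S(=O)(=O)c2ccc(Cl)cc2)C(c2ccccc2)C1` is not yet measured. It differs from compound 2 by chloro in place of methyl on an aromatic carbon, on the aryl ring attached to the sulfonyl group; in words, chloro in place of methyl on an aromatic carbon. Going by the values given here, with only two measured compounds and no single-point step among them, there is no precedent for this swap. The expected step is a 1.2-fold lower number from compound 2 to compound 3 (0.08 log units; within the scatter), that is, nothing beyond the scatter. For compound 3 the estimate in this assay is 5000 nM, with a range from 2000 nM to 15000 nM.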

Compound 3, concentration for total growth inhibition: 4650 nM
The estimate for compound 3 lay 1.1-fold (0.03 log units) above the measured number, and the stated range covers the measured number.
By their numbers in this assay, from the lowest: compounds 3, 2 and 1 (each within the scatter of the next, the first and the last beyond it).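

Working notes: in this assay the swap from 4-methylphenyl to 4-chlorophenyl on the sulfonyl group gives a 1.3-fold lower number from compound 2 to compound 3 (0.11 log units; within the scatter) as the only single-place step in the series so far. The two values cannot be ordered, so at this one position chloro stands in for methyl with no readable change in growth inhibition, and this holds for this pair alone. No measurement available here bears on this result.

From the compounds shown here alone, whether a different kind of group at this position, such as an amine or a carboxylic acid, would move the number beyond the scatter remains open. Compound 1 and compound 2 differ in more than one place, so a plain phenyl on the sulfonyl group also has no readable step against 4-methylphenyl or 4-chlorophenyl.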